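Lengthening the hydroxycarbamoyl chain from compound 2 to compound 3

The compounds below may be only part of what the source reports. "The series", "measured", "known", "first", "only" and "open" are said of these compounds alone.

In a functional assay on HCT-116 cells (Homo sapiens) for antiproliferative activity, read by MTT assay, with a stated time of 72 h (a lower number here means a stronger inhibitor, a higher number a weaker inhibitor), compound 1 `O=C(CCCn1cc(-c2ncnc3[nH]ccc23)cn1)NO` reads > 100000 nM as a limit of the assay, not a number. Going by the values given here, compound 2 `O=C(CCCCCCCn1cc(-c2ncnc3[nH]ccc23)cn1)NO` gives 11800 nM and is the only true number so far. Compound 3 `O=C(CCCCCCCCCCn1cc(-c2ncnc3[nH]ccc23)cn1)NO` carries 3-(hydroxycarbamoyl)propyl in place of hydroxycarbamoyl on a saturated chain carbon, seven bonds along the chain from an aromatic nitrogen. Among the compounds with values here, the one measured step that bears on this is the earlier chain extension, with an at least 8.4-fold lower number from compound 1 to compound 2 (0.92 log units; beyond the scatter) as its size, and that size rests on a limit (the limit of > 100000 nM in this assay, at which 1 of the 2 values shown sits). A smaller step in the same direction is expected, namely a 2.4-fold lower number from compound 2 to compound 3 (0.37 log units; beyond the scatter) in this assay as estimated here. Compound 3 is expected at 5000 nM with an estimated range from 1200 nM to 25000 nM by this reckoning.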

Compound 3, half-maximal inhibitory concentration: 41100 nM
Compound 3: middle estimate off by 8.2-fold (0.91 log units), on the low side; the whole stated range lies below it.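

In this assay, lengthening the chain no longer lowers the number: the earlier gain reverses, with a 3.5-fold higher number from compound 2 to compound 3 (0.54 log units; beyond the scatter). The response to chain length at this position is therefore not a steady one, and the chain of compound 2 gives a lower number than the longer chain of compound 3. The reading for the shorter chain of compound 1 is a limit, not a number: the limit of > 100000 nM in this assay, at which 1 of the 3 values shown sits.

From the compounds shown here alone, whether a chain longer than that of compound 2 but shorter than that of compound 3 would give a lower number remains open. So does the effect of a carboxylic acid in place of hydroxycarbamoyl.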